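Branching the thioether chain: expected cytotoxicity of compound 4

A few compounds are considered here, and "the series" means these few. Any claim that something is new, unique, unknown or untested is made for them only; others in the source may bear on it.

Of the compounds shown here, three built on one shared core have been tested in an ADME assay on MT4 cells (Homo sapiens) for activation, read by MTT assay; on this read-out lower numbers stand for higher toxicity in this test and higher numbers for lower toxicity in this test. Compound 1 `CCCSc1nc(C(C)c2c(F)cccc2Cl)cc(=O)[nH]1` carries a propylsulfanyl group. In this assay compound 1 gives > 75000 nM, which is a limit of the assay and not a number. Compound 2 `CCCCSc1nc(C(C)c2c(F)cccc2Cl)cc(=O)[nH]1` differs from compound 1 by methyl in place of hydrogen on a saturated chain carbon, three bonds along the chain from a sulfur. In this assay compound 2 gives > 73000 nM, again a limit. The step that the two limits leave unreadable from compound 1 to compound 2. Compound 3 `CCCSc1nc(C(C)c2c(F)cccc2Cl)c(C)c(=O)[nH]1` differs from compound 1 by methyl in place of hydrogen on an aromatic carbon, and this is the whole difference between the two cores. In this assay compound 3 gives > 1500 nM, also a limit. The step that the two limits leave unreadable from compound 1 to compound 3.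

Compound 4 `CCC(C)Sc1nc(C(C)c2c(F)cccc2Cl)c(C)c(=O)[nH]1` has not yet been measured. It differs from compound 3 by methyl in place of hydrogen on a saturated chain carbon bound to a saturated chain carbon and a sulfur. Among the measured compounds shown here, this is the same kind of change as the one from compound 1 to compound 2, not the same change: there the methyl entered on a saturated chain carbon, three bonds along the chain from a sulfur, whereas here it enters on a saturated chain carbon bound to a saturated chain carbon and a sulfur.

For the measured compounds named here, all three measured values are limits the limit of > 1500 nM in this assay, at which 1 of the 3 values shown sits, the limit of > 73000 nM in this assay, at which 1 of the 3 values shown sits (the limit of > 75000 nM in this assay, at which 1 of the 3 values shown sits), so no step among them can be read. The expectation for compound 4 therefore rests on the limit of compound 3, > 1500 nM, and on the small size of the change. For compound 4 the step that the limit leaves unreadable from compound 3 to compound 4 is expected to be small. The estimated value for compound 4 is 30000 nM, with an expected range from 1500 nM to 100000 nM, and this assay will most likely again report only a limit.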

Compound 4, half-maximal cytotoxic concentration: > 1500 nM
Compound 4 gave a limit, no number (the forecaster's own chance of this, stated with the estimate: 80%); the middle value is on the limit's open side.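

In this assay compound 4 gives > 1500 nM as a limit of the assay and not a number. Compound 3 also gives only a limit, so the size of the change from compound 3 to compound 4 cannot be read. None of the compounds shown gives a number in this assay, so they leave open whether going from propylsulfanyl to (sec-butyl)sulfanyl changes the toxicity at all.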